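Chalcone-lactam series: para substituent swap on the cinnamoyl ring

A few compounds are considered here, and "the series" means these few. Any claim that something is new, unique, unknown or untested is made for them only; others in the source may bear on it.

Notes on the shared core. Compound 1 `O=C(COc1ccc(C(=O)/C=C/c2ccccc2Cl)cc1)N[C@H]1CCOC1=O` gives 27100 nM in a functional assay on MGC-803 cells (Homo sapiens) for antiproliferative activity, read by MTT assay, with a stated time of 72 h; a lower number here means a stronger inhibitor, a higher number a weaker inhibitor. Compound 2 `O=C(COc1ccc(C(=O)/C=C/c2ccc(F)c(F)c2)cc1)N[C@H]1CCOC1=O` reaches only the limit > 64000 nM in this assay. Compound 3 `O=C(COc1ccc(C(=O)/C=C/c2ccc(F)cc2)cc1)N[C@H]1CCOC1=O` likewise sits at the limit > 64000 nM in this assay, so its position is known only as a boundary; this is the limit of > 64000 nM in this assay, at which 2 of the 3 values shown sit. The steps of an at least 2.3-fold higher number from compound 1 to compound 2 (0.37 log units; beyond the scatter) and an at least 2.3-fold higher number from compound 1 to compound 3 (0.37 log units; beyond the scatter) both weaken, while a step that the two limits leave unreadable from compound 2 to compound 3 cannot be read. Compound 4 `CC(C)c1ccc(/C=C/C(=O)c2ccc(OCC(=O)N[C@H]3CCOC3=O)cc2)cc1` differs from compound 3 by isopropyl in place of fluoro on an aromatic carbon. Among the compounds with values here, no measured step touches an isopropyl group, so the direction of an at least 1.2-fold lower number from compound 3 to compound 4 (0.10 log units; that floor lies within the scatter) is an estimate without direct precedent. Compound 4 is expected near 50000 nM, within 15000 nM to 150000 nM, with a real chance of another limit.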

Compound 4, half-maximal inhibitory concentration: 16800 nM
Beside the measured number, compound 4's estimate is 3.0-fold (0.47 log units) above it, within the range that was stated.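

Isopropyl on the aromatic carbon para to a large group gives a measured value where fluoro gave only a limit, with an at least 3.8-fold lower number from compound 3 to compound 4 (0.58 log units; beyond the scatter) and an at least 3.8-fold lower number from compound 2 to compound 4 (0.58 log units; beyond the scatter) pointing the same way. Against the 2-chlorophenyl compound, a 1.6-fold lower number from compound 1 to compound 4 (0.21 log units; within the scatter) sets no order between the two in this assay and shows only that the two groups read alike. The two larger steps are floors set by limits, not sizes: the limit of > 64000 nM in this assay, at which 2 of the 4 values shown sit.

Open remains whether the effect belongs to isopropyl itself or extends to a methyl or tert-butyl group at this carbon. An amine or a carboxylic acid there is equally untested in the compounds shown.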